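Allyloxy oxime series: shortening the side chain to ethoxy

A few compounds are considered here, and "the series" means these few. Any claim that something is new, unique, unknown or untested is made for them only; others in the source may bear on it.

Compound 1 `C=CCO/N=C/c1c(N)ncnc1Oc1ccc2[nH]c(C)cc2c1F` gives 21 nM in a functional assay on A-375 cells (Homo sapiens) for antiproliferative activity (on this read-out higher numbers stand for weaker inhibition and lower numbers for stronger inhibition), the lowest of the two numbers recorded so far. Its only measured comparator, compound 2 `Cc1cc2c(F)c(Oc3ncnc(N)c3/C=N/OCc3ccccc3)ccc2[nH]1`, gives 62 nM in this assay; the step of a 3.0-fold higher number from compound 1 to compound 2 (0.47 log units; beyond the scatter) is modest but beyond the scatter, and it comes from phenyl in place of vinyl on a saturated chain carbon bound to an oxygen on an unsaturated carbon.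

Compound 3 `CCO/N=C/c1c(N)ncnc1Oc1ccc2[nH]c(C)cc2c1F` is not yet measured. It differs from compound 1 as follows: methyl in place of vinyl on a saturated chain carbon bound to an oxygen on an unsaturated carbon Cut one bond further out the same difference reads allyl to ethyl. Among the compounds with values here, the single measured step at this position runs the other way, toward the larger group, and raised the number by a 3.0-fold higher number from compound 1 to compound 2 (0.47 log units; beyond the scatter). Within the data shown here, no measured step goes from vinyl toward a smaller group here, so neither direction is supported by data, and the expected step is a 1.2-fold higher number from compound 1 to compound 3 (0.08 log units; within the scatter), within or only just beyond the scatter. Compound 3 is therefore estimated to give about 25 nM in this assay, within a range from 10 nM to 70 nM.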

Compound 3, half-maximal inhibitory concentration: 27 nM
Estimate against measurement, compound 3: 1.1-fold (0.03 log units) below; the measured number falls inside the stated range.
By their numbers in this assay, from the lowest: compounds 1 and 3 (each within the scatter of the next); then compound 2.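

In this assay, the first step toward a smaller group at this position, methyl in place of vinyl, gives a 1.3-fold higher number from compound 1 to compound 3 (0.11 log units; within the scatter), so allyloxy and ethoxy cannot be told apart on this read-out, and compound 3 stays level with compound 1 without the double bond outside aromatic rings. Against the phenyl compound the same methyl gives a 2.3-fold lower number from compound 2 to compound 3 (0.36 log units; beyond the scatter), so both steps beyond the scatter at this place, this one and a 3.0-fold higher number from compound 1 to compound 2 (0.47 log units; beyond the scatter), involve phenyl, while the step between the two non-aromatic groups stays within it. Nothing available explains why phenyl separates from vinyl and methyl here.

Going by these compounds, three groups on one chain carbon give only a thin view of this position, and whether a longer chain such as n-butyl, a terminal amine or a carboxylic acid on the chain would stay level with compounds 1 and 3 remains open. Also open is whether the same ranking would hold on any read-out other than this assay, which is the only one shown for these compounds.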